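Iodine for Fluorine on the Arylamine Arm of a Quinone Core

The source may hold more compounds than are shown below. What is called first, only, known or untested is meant among the compounds shown, and "the series" means these compounds.

All three compounds here share one core, a quinone fused to a sugar-bearing ring system, and carry an arylamine arm; they were tested in a functional assay on ECa-109 cells for inhibition, with ECa-109 cell line (Homo sapiens) as the target, read by sulforhodamine B assay; on this read-out lower numbers stand for stronger inhibition and higher numbers for weaker inhibition. Compound 1, with structure `O=C1C(Nc2ccc(I)cc2)=CC(=O)c2c1nc1n2[C@H]2OC[C@@H](O)[C@H]2OC1`, gives 2530 nM in this assay. Compound 2, with structure `O=C1C=C(Nc2ccccc2F)C(=O)c2c1nc1n2[C@H]2OC[C@@H](O)[C@H]2OC1`, gives 2760 nM in this assay. Compound 2 thus has the higher of the two numbers, but its gap to compound 1 falls within the scatter of repeated measurements, so the two cannot be told apart.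

Compound 3, with structure `O=C1C=C(Nc2ccc(I)cc2)C(=O)c2c1nc1n2[C@H]2OC[C@@H](O)[C@H]2OC1`, has not yet been measured. It differs from compound 2 by 4-iodophenyl in place of 2-fluorophenyl on an amine nitrogen. The same 4-iodophenyl group already appears in compound 1, where it sits on the other side of the quinone ring, and compound 1 and compound 2 sit within the scatter of each other. No change beyond the scatter is therefore expected from compound 2 to compound 3; the expected step is a 1.1-fold lower number from compound 2 to compound 3 (0.03 log units; within the scatter). For compound 3 the estimate in this assay is 2600 nM, with a range from 1200 nM to 5500 nM.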

Compound 3, half-maximal inhibitory concentration: 2300 nM
For compound 3 the middle estimate is 1.1-fold (0.05 log units) above the measured one, and the stated range covers the measured number.
By their numbers in this assay, from the lowest: compounds 3, 1 and 2 (each within the scatter of the next).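

In this assay, putting 4-iodophenyl in place of 2-fluorophenyl on the amine nitrogen gives a 1.2-fold lower number from compound 2 to compound 3 (0.08 log units; within the scatter), so these two compounds cannot be told apart. Compound 1 and compound 2 differ both in the aryl group and in where the arylamine arm sits on the shared core, so their closeness could not speak for either change alone, whereas this new pair keeps the arm in place and changes only the aryl group. At this position, then, this swap of one halogen-bearing phenyl ring for another leaves the number unchanged within the scatter, and nothing available explains that result.

This single swap changes the halogen and its place on the phenyl ring together, so a pair with 4-fluorophenyl or 2-iodophenyl would be needed to follow each change separately. On these data alone, it also remains open whether a group of a different kind on the amine nitrogen, such as a simple alkyl chain or a phenyl ring carrying a carboxylic acid, would shift the number beyond the scatter.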